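A butoxyphenyl-to-methylphenyl swap on two hydrazide cores

The compounds below may be only part of what the source reports. "The series", "measured", "known", "first", "only" and "open" are said of these compounds alone.

Compound 1 `CCCCOc1ccc(C(=O)NNC(=O)c2ccc(NS(=O)(=O)c3cnc(O)nc3O)cc2)cc1` and compound 3 `CCCCOc1ccc(C(=O)NNC(=O)c2ccccc2NS(=O)(=O)c2cnc(O)nc2O)cc1` are built from the same atoms joined differently; the difference between the two cores is not broken down here. In a functional assay on SGC-7901 cells (Homo sapiens) for antiproliferative activity, read by MTT assay, with a stated time of 24 h (on this read-out lower numbers stand for stronger inhibition and higher numbers for weaker inhibition), compound 1 gives 14700 nM, and compound 3 gives 6890 nM. Compound 2 `Cc1ccccc1C(=O)NNC(=O)c1ccc(NS(=O)(=O)c2cnc(O)nc2O)cc1` carries 2-methylphenyl in place of 4-butoxyphenyl on a carbonyl carbon. In this assay compound 2 reaches only a limit, > 20000 nM. That gives an at least 1.3-fold higher number from compound 1 to compound 2 (0.13 log units; that floor lies within the scatter), its floor set by the limit of > 20000 nM in this assay, at which 1 of the 3 values shown sits. Compound 4 `Cc1ccccc1C(=O)NNC(=O)c1ccccc1NS(=O)(=O)c1cnc(O)nc1O` carries the same change on the core of compound 3: 2-methylphenyl in place of 4-butoxyphenyl on a carbonyl carbon. In this assay the expected step is a 2.6-fold higher number from compound 3 to compound 4 (0.42 log units; beyond the scatter), a weakening, since the same change gave an at least 1.3-fold higher number from compound 1 to compound 2 (0.13 log units; that floor lies within the scatter). Compound 4 is therefore estimated at 18000 nM, between 8000 nM and 45000 nM, with a real chance that only a limit is reported.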

Compound 4, half-maximal inhibitory concentration: 13000 nM
Estimate against measurement, compound 4: 1.4-fold (0.14 log units) above; low and high end bracket the measured number.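

In this assay, 2-methylphenyl in place of 4-butoxyphenyl on a carbonyl carbon gives a 1.9-fold higher number from compound 3 to compound 4 (0.28 log units; within the scatter), so on this core the change shows no clear effect. Set beside the earlier step, this result neither shows that the change carries over from one core to the other with the same size nor shows that it does not: the same change on two cores in this assay, an at least 1.3-fold higher number (0.13 log units; that floor lies within the scatter) from compound 1 to compound 2 and a 1.9-fold higher number (0.28 log units; within the scatter) from compound 3 to compound 4; the limit leaves it open whether they differ. The comparison rests on one limit, that of compound 2: the limit of > 20000 nM in this assay, at which 1 of the 4 values shown sits.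

The compounds shown leave open what a longer alkoxy chain, an amine or a carboxylic acid on that phenyl ring would do on either core. They also leave open whether any such group would produce a step beyond the scatter.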